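The source may hold more compounds than are shown below. What is called first, only, known or untested is meant among the compounds shown, and "the series" means these compounds.

Compound 3 `O=C(Nc1cc(-c2ccccc2)nn1-c1ccccc1F)c1ccccc1` carries the highest number of the three measured compounds in an assay on HEK293 cells for displacement of a labelled ligand from metabotropic glutamate receptor 5 (Rattus norvegicus) (on this read-out lower numbers stand for stronger inhibition and higher numbers for weaker inhibition), where compound 3 gives 2700 nM against stronger showings elsewhere: compound 1 `COc1cccc(C(=O)Nc2cc(-c3ccccc3)nn2-c2ccccc2)c1` gives 1290 nM and compound 2 `O=C(Nc1cc(-c2ccccc2)nn1-c1ccccc1)c1ccc([N+](=O)[O-])cc1` gives 250 nM in the same test. Compound 4 `N#Cc1cccc(-n2nc(-c3ccccc3)cc2NC(=O)c2ccccc2)c1` has not yet been measured. It differs from compound 3 at one place: 3-cyanophenyl in place of 2-fluorophenyl on an aromatic nitrogen. For the measured compounds named here, the only single-point step measured so far is a 5.2-fold lower number from compound 1 to compound 2 (0.71 log units; beyond the scatter), and that step concerns the group on the carbonyl carbon rather than the group on the aromatic nitrogen, so it does not bear directly on the change from compound 3 to compound 4. Going by the values given here, no measured pair shows what exchanging the ring on the aromatic nitrogen does, and the direction of this step is therefore open. Compound 4 is expected to give an estimated 1500 nM with a likely range from 400 nM to 5000 nM in this assay. That expectation amounts to an estimated step of a 1.8-fold lower number from compound 3 to compound 4 (0.26 log units; within the scatter) in this assay.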

Compound 4, inhibition constant: > 10000 nM
Compound 4: no number, only a limit; the forecaster's own chance of this, stated with the estimate: 5%; middle value at least 6.6-fold (0.82 log units) away from the limit.
By their numbers in this assay, from the lowest: compound 2; then compound 1; then compound 3. At a limit, above all of these: compound 4.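

The ring on the aromatic nitrogen clearly matters in this assay: 3-cyanophenyl in place of 2-fluorophenyl gives an at least 3.7-fold higher number from compound 3 to compound 4 (0.56 log units; beyond the scatter). For the compounds shown here, the one step measured earlier concerned the group on the carbonyl carbon, so this is the first evidence that a change on the aromatic nitrogen can also shift the result beyond the usual scatter. Compound 4 sits at a limit rather than at a number, so the true size of the step stays unknown and only its minimum is given: the limit of > 10000 nM in this assay, at which 1 of the 4 values shown sits.

The compounds shown cannot separate the loss of the fluorine from the arrival of the nitrile, as both change in this single step. They also leave open how this ring would behave carrying an amine or a carboxylic acid.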